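A few compounds are considered here, and "the series" means these few. Any claim that something is new, unique, unknown or untested is made for them only; others in the source may bear on it.

Of the compounds shown here, three on a shared core have been read in an ADME assay on microsomes from liver (Mus musculus) for metabolic stability, read by LC-MS, with a stated time of 10 min; a lower number here means that less of the compound is left, a higher number that more of the compound is left. Compound 1 (`CN(C[C@H]1Cc2c(cccc2N2CCNC(C)(C)C2)CN1)[C@H]1CCCc2cccnc21`) gives 44%, compound 2 (`CN(C[C@H]1Cc2c(cccc2N2CCN(Cc3ccccn3)CC2)CN1)[C@H]1CCCc2cccnc21`) gives 40.4% and compound 3 (`C[C@@H]1CN(c2cccc3c2C[C@H](CN(C)[C@H]2CCCc4cccnc42)NC3)C[C@H](C)N1C`) gives 39.6%. Compound 2 therefore stands within the usual scatter of both other compounds.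

Compound 4 (`CN(C[C@H]1Cc2c(cccc2N2CCN(c3ccccn3)CC2)CN1)[C@H]1CCCc2cccnc21`) departs from compound 2 in one place: pyridin-2-yl in place of (pyridin-2-yl)methyl on an amine nitrogen in a ring. In short, pyridin-2-yl stands in place of (pyridin-2-yl)methyl on an amine nitrogen in a ring. Going by the values given here, only one measured step offers a guide, and only a loose one, since it places 3,4,5-trimethylpiperazin-1-yl in place of 3,3-dimethylpiperazin-1-yl on an aromatic carbon. Going by the size of that step, a number 4.4 percentage points lower from compound 1 to compound 3 (within the scatter), no change beyond the scatter is expected in this assay, and no direction can be firmly assigned. The expected step is a number 2.4 percentage points lower from compound 2 to compound 4 (within the scatter), which is within the scatter. The estimate for compound 4 is 38%, with an expected range from 22% to 54%.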

Compound 4, percent of the compound remaining: 46.1%
Estimate against measurement, compound 4: 8.1 percentage points below; low and high end bracket the measured number.
By their numbers in this assay, from the lowest: compounds 3, 2, 1 and 4 (each within the scatter of the next).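

In this assay, the change at this amine nitrogen in a ring gives a number 5.7 percentage points higher from compound 2 to compound 4 (within the scatter), so pyridin-2-yl and (pyridin-2-yl)methyl cannot be told apart here. The earlier step had varied only the substituted piperazin-1-yl groups on an aromatic carbon, whereas this one shows that, with the rest of the molecule held constant, the swap at this nitrogen also stays within the usual scatter. Nothing shown gives a reason for this result.

The compounds shown leave open whether the pyridine nitrogen matters at this position, which a phenyl or benzyl group on the same nitrogen would test. They also leave open whether a longer chain, such as 2-(pyridin-2-yl)ethyl, or a carboxylic acid there would move the number beyond the scatter.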